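Swapping 3-Methoxyphenyl for 4-Fluorophenyl on a Hydroxylated Core

A few compounds are considered here, and "the series" means these few. Any claim that something is new, unique, unknown or untested is made for them only; others in the source may bear on it.

Measured in an ADME assay on THP-1 cells (Homo sapiens) for cytotoxicity, read by flow cytometry and propidium iodide staining, with a stated time of 72 h; a higher number here means a weaker inhibitor, a lower number a stronger inhibitor:
- compound 1 `CC(=O)Nc1ccc2oc(-c3ccccc3)cc(=O)c2c1`: 97000 nM
- compound 2 `COc1cccc(-c2cc(=O)c3cc(NC(C)=O)ccc3o2)c1`: 10000 nM
- compound 3 `COc1cccc(-c2oc3ccc(NC(C)=O)cc3c(=O)c2O)c1`: 50000 nM

Not yet measured: compound 4 `CC(=O)Nc1ccc2oc(-c3ccc(F)cc3)c(O)c(=O)c2c1`

Compound 3 gives 50000 nM, which lies within the scatter of compound 1 at 97000 nM. Both numbers are higher than that of compound 2 at 10000 nM. Compound 4 carries 4-fluorophenyl in place of 3-methoxyphenyl on an aromatic carbon. The hydroxy group stays, so the methoxy is what goes, and fluorine arrives.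

Among the measured compounds shown here, two measured steps bear on this. The closer guide is a 9.7-fold lower number from compound 1 to compound 2 (0.99 log units; beyond the scatter), seen with methoxy in place of hydrogen on an aromatic carbon. Losing the methoxy could therefore push the number upward. The second is a 5.0-fold higher number from compound 2 to compound 3 (0.70 log units; beyond the scatter), seen with hydroxy in place of hydrogen on an aromatic carbon. With that hydroxy present, compound 3 at 50000 nM already sits close to the methoxy-free compound 1, so little of the methoxy gain may remain to lose. For the measured compounds named here, no measured compound here carries fluorine, so its contribution is unknown.

The estimated step is a 1.6-fold higher number from compound 3 to compound 4 (0.20 log units; within the scatter), so a change beyond the scatter is not expected, although any drift is expected to be upward. Compound 4 is expected at 80000 nM, with an estimated range of 30000 nM to 200000 nM.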

Compound 4, half-maximal inhibitory concentration: 26000 nM
Estimate against measurement, compound 4: 3.1-fold (0.49 log units) above; measured number below the stated range.
By their numbers in this assay, from the lowest: compound 2; then compounds 4, 3 and 1 (each within the scatter of the next, the first and the last beyond it).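

In this assay, putting 4-fluorophenyl in place of 3-methoxyphenyl on the core that keeps its hydroxy group gives a 1.9-fold lower number from compound 3 to compound 4 (0.28 log units; within the scatter), so this aromatic carbon next to the ring oxygen tolerates the exchange of one substituted phenyl for another without a change beyond the scatter. The earlier compounds shown here showed only that adding a methoxy to the plain phenyl, on the core without the hydroxy group, gave a 9.7-fold lower number from compound 1 to compound 2 (0.99 log units; beyond the scatter); the new result shows that, with the hydroxy group present, the methoxy can leave without a shift of that kind, provided a fluorine enters on the same ring. Nothing shown here explains why the number holds steady in this exchange.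

Since the methoxy leaves and the fluorine enters in a single step, their separate contributions cannot be told apart, and a plain phenyl on the hydroxylated core would be the compound to separate them. On these data alone, it also remains open whether this tolerance extends to a phenyl ring carrying an amine or a carboxylic acid in place of the fluorine.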